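Swapping a pyridine for a methylfuran on a shared core

The compounds below may be only part of what the source reports. "The series", "measured", "known", "first", "only" and "open" are said of these compounds alone.

Of the compounds shown here, three have been measured in a functional assay for inhibition, with Homo sapiens as the target; on this read-out higher numbers stand for weaker inhibition and lower numbers for stronger inhibition. Compound 1 `Cc1cccc(Nc2nccc(-c3ccc(C)o3)n2)c1` gives 2000 nM. Compound 2 `Cc1cccc(Nc2nccc(-c3ccccn3)n2)c1` gives 700 nM, and compound 3 `COc1cccc(Nc2nccc(-c3ccccn3)n2)c1` gives 200 nM, the lowest of the three numbers.

Two single changes link these compounds. The change from compound 2 to compound 3 brings a 3.5-fold lower number from compound 2 to compound 3 (0.54 log units; beyond the scatter), a gain in inhibition. The change from compound 2 to compound 1 is 5-methylfuran-2-yl in place of pyridin-2-yl on an aromatic carbon, and it brings a 2.9-fold higher number from compound 2 to compound 1 (0.46 log units; beyond the scatter), a loss in inhibition.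

Compound 4 `COc1cccc(Nc2nccc(-c3ccc(C)o3)n2)c1` has not yet been measured. It differs from compound 3 by 5-methylfuran-2-yl in place of pyridin-2-yl on an aromatic carbon. For the measured compounds named here, this is the same kind of change as the one from compound 2 to compound 1, made on a different core: the two cores differ by methoxy in place of methyl on an aromatic carbon. Around the place of the change the only difference is that the group met in compound 3 and compound 4 is one of 9 heavy atoms, where in compound 2 and compound 1 it is one of 8 heavy atoms.

Because the same kind of change gave a 2.9-fold higher number from compound 2 to compound 1 (0.46 log units; beyond the scatter), compound 4 is expected to give about 600 nM in this assay. That estimate corresponds to an expected 3.0-fold higher number from compound 3 to compound 4 (0.48 log units; beyond the scatter), a step of roughly the earlier size. Going by the values given here, for compound 4 the expected range runs from 250 nM to 1500 nM, since only one earlier example of this change is available.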

Compound 4, half-maximal inhibitory concentration: 1500 nM
Compound 4: middle estimate off by 2.5-fold (0.40 log units), on the low side; the measured number falls inside the stated range.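

In this assay, putting 5-methylfuran-2-yl in place of pyridin-2-yl also weakens inhibition on the methoxy core, giving a 7.5-fold higher number from compound 3 to compound 4 (0.88 log units; beyond the scatter), so the change carries over in direction, and the two steps do not differ in size beyond the scatter: the same change on two cores in this assay, a 2.9-fold higher number (0.46 log units; beyond the scatter) from compound 2 to compound 1 and a 7.5-fold higher number (0.88 log units; beyond the scatter) from compound 3 to compound 4, 2.6-fold (0.42 log units) apart, within the scatter of two such steps Seen the other way, methoxy in place of methyl gives a 1.3-fold lower number from compound 1 to compound 4 (0.12 log units; within the scatter) when 5-methylfuran-2-yl is present, so there it brings no real difference, yet this step cannot be told apart from the step seen with pyridin-2-yl: the same change on two cores in this assay, a 3.5-fold lower number (0.54 log units; beyond the scatter) from compound 2 to compound 3 and a 1.3-fold lower number (0.12 log units; within the scatter) from compound 1 to compound 4, 2.6-fold (0.42 log units) apart, within the scatter of two such steps These two matched pairs support a loss of inhibition from this swap on these two cores only; they do not fix the size of the loss, do not show that it would appear on any other core, and say nothing of why it occurs.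

The compounds shown leave open whether a plain furan-2-yl, a thiophene or a phenyl ring in place of pyridin-2-yl would bring a similar loss. They also leave open how the swap would behave on a core carrying a chlorine atom or an amine where the methyl and methoxy groups stand.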